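Swapping an aromatic ring for a butyl chain

The compounds below may be only part of what the source reports. "The series", "measured", "known", "first", "only" and "open" are said of these compounds alone.

Of the compounds shown here, three sharing one core have been measured in an assay on isolated protein for inhibition of myosin-2 (Bos taurus), read by spectrophotometry, with a stated time of 24 min; a higher number here means a weaker inhibitor, a lower number a stronger inhibitor. Compound 1 `C/C(=N\CCO)c1c(O)c2ccccc2oc1=O` carries a hydroxymethyl group on a saturated chain carbon bound to a double-bonded nitrogen and gives 92000 nM in this assay. Compound 2 `C/C(=N\Cc1cccnc1)c1c(O)c2ccccc2oc1=O` carries pyridin-3-yl at that place and gives 17000 nM, a step of a 5.4-fold lower number from compound 1 to compound 2 (0.73 log units; beyond the scatter). Compound 3 `C/C(=N\Cc1ccccc1C)c1c(O)c2ccccc2oc1=O` carries 2-methylphenyl there. In this assay compound 3 reports only a limit of the assay, >= 100000 nM. Compound 3 thus sits at the limit, as the limit of >= 100000 nM in this assay, at which 1 of the 3 values shown sits, records; the step into it from compound 2 was an at least 5.8-fold higher number from compound 2 to compound 3 (0.76 log units; beyond the scatter), while an at least 1.0-fold higher number from compound 1 to compound 3 (0.03 log units; that floor lies within the scatter).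

The next compound, compound 4 `CCCCC/N=C(\C)c1c(O)c2ccccc2oc1=O`, changes this group: butyl in place of 2-methylphenyl on a saturated chain carbon bound to a double-bonded nitrogen. For the measured compounds named here, no measured step replaces an aromatic ring with a plain chain, so the closest guides are the two steps into compound 3 already quoted, together with the observation that compound 1, which also carries a chain rather than a ring at this place, sits close to the limit reached by compound 3. Compound 4 is therefore expected to differ little, an estimated step of a number no higher from compound 3 to compound 4 (the limit leaves the size open). For compound 4 the estimate in this assay is 100000 nM, with a range from 30000 nM to 300000 nM.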

Compound 4, half-maximal inhibitory concentration: 6700 nM
Estimate against measurement, compound 4: 15-fold (1.17 log units) above, and the stated range ends above it.
By their numbers in this assay, from the lowest: compound 4; then compound 2; then compound 1. At a limit, above all of these: compound 3.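

In this assay, a plain chain at this place is not the dead end that compound 1 suggested: butyl in place of 2-methylphenyl gives an at least 14-fold lower number from compound 3 to compound 4 (1.17 log units; beyond the scatter), so an aromatic ring is not needed for a low number here. Butyl also improves on the one ring that had helped, with a 2.5-fold lower number from compound 2 to compound 4 (0.40 log units; beyond the scatter), and the two chains turn out to be far apart, with a 14-fold lower number from compound 1 to compound 4 (1.14 log units; beyond the scatter), so what matters is the kind of chain and not merely the absence of a ring. The step from the 2-methylphenyl compound can only be read as a minimum, since compound 3 remains at a limit of the assay: the limit of >= 100000 nM in this assay, at which 1 of the 4 values shown sits.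

The compounds shown cannot separate the effect of the ring itself from that of its methyl group, and a plain phenyl group at this place would be needed to tell them apart. They also leave open whether a longer chain such as hexyl would lower the number further, and whether an amine or a carboxylic acid at the end of the butyl chain would cost as much as the hydroxy group of compound 1 appears to.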